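Moving the trifluoromethylphenyl group on the shared core

The source may hold more compounds than are shown below. What is called first, only, known or untested is meant among the compounds shown, and "the series" means these compounds.

Compound 3 `Oc1cccc(-c2cc(-c3ccccc3C(F)(F)F)cc(-c3ccccc3O)n2)c1` gives 7250 nM in a functional assay on DU-145 cells (Homo sapiens) for inhibition (a higher number here means a weaker inhibitor, a lower number a stronger inhibitor), the lowest of the two numbers available; the nearest is compound 1 `Oc1cccc(-c2cc(-c3ccccc3F)cc(-c3ccccc3O)n2)c1` at 35600 nM. Among the measured compounds shown here, the step of a 4.9-fold lower number from compound 1 to compound 3 (0.69 log units; beyond the scatter) is the only single change measured so far. Compound 2 `Oc1ccccc1-c1cc(-c2ccc(C(F)(F)F)cc2)cc(-c2ccccc2O)n1` reaches only the assay limit, > 50000 nM. Compound 4 `Oc1cccc(-c2cc(-c3ccc(C(F)(F)F)cc3)cc(-c3ccccc3O)n2)c1` differs from compound 3 by 4-(trifluoromethyl)phenyl in place of 2-(trifluoromethyl)phenyl on an aromatic carbon. For the measured compounds named here, no measured step covers this change directly; compound 2, which also carries the 4-(trifluoromethyl)phenyl group but differs elsewhere as well, sits at the limit (the limit of > 50000 nM in this assay, at which 1 of the 3 values shown sits), and compound 1 is weaker than compound 3. Compound 4 is therefore expected to be weaker, the estimated step being a 3.4-fold higher number from compound 3 to compound 4 (0.54 log units; beyond the scatter). The expected value for compound 4 is 25000 nM, between 8000 nM and 80000 nM.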

Compound 4, half-maximal inhibitory concentration: > 50000 nM
Compound 4: no number, only a limit; the forecaster's own chance of this, stated with the estimate: 35%; at least 2.0-fold (0.30 log units) between middle value and limit.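

In this assay, moving the trifluoromethyl group on this phenyl ring matters, with the rest of the shared core unchanged (an at least 6.8-fold higher number from compound 3 to compound 4 (0.83 log units; beyond the scatter)). Against the 2-fluorophenyl group, 4-(trifluoromethyl)phenyl gives no readable loss (an at least 1.4-fold higher number from compound 1 to compound 4 (0.14 log units; that floor lies within the scatter)), and that floor lies within the scatter. The step between compound 2 and compound 4 cannot be read, as both are limits of the assay: the limit of > 50000 nM in this assay, at which 2 of the 4 values shown sit.

From the compounds shown here alone, whether a phenyl group carrying an amine or a carboxylic acid at this position would retain inhibition stays open. The effect of the 3-hydroxyphenyl group in place of 2-hydroxyphenyl also remains unresolved.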